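Replacing the pyrazole of compound 3

A few compounds are considered here, and "the series" means these few. Any claim that something is new, unique, unknown or untested is made for them only; others in the source may bear on it.

Measured in an ADME assay (liver) for metabolic stability, with Liver microsome (Rattus norvegicus) as the target, using microsomes and NADPH, with a stated time of 30 min, tested at 1 uM; on this read-out higher numbers stand for fast clearance and lower numbers for slow clearance:
Compound 1 `COc1cc(C(O)(C(F)(F)F)C(F)(F)F)cnc1N1CCN(S(=O)(=O)c2ccc(N)nc2)CC1`: < 14 mL.min-1.g-1, a limit of the assay
Compound 2 `Nc1ccc(S(=O)(=O)N2CCN(c3ncc(C(O)(C(F)(F)F)C(F)(F)F)cc3C#CCCO)CC2)cn1`: 68 mL.min-1.g-1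
Compound 3 `CC(C)(C)n1cc(-c2cc(C(O)(C(F)(F)F)C(F)(F)F)cnc2N2CCN(S(=O)(=O)c3ccc(N)nc3)CC2)cn1`: 459 mL.min-1.g-1

Compound 3 holds the highest of the two true numbers, and its nearest neighbour lies well under it, with a 6.8-fold higher number from compound 2 to compound 3 (0.83 log units; beyond the scatter). Compound 4 `Nc1ccc(S(=O)(=O)N2CCN(c3ncc(C(O)(C(F)(F)F)C(F)(F)F)cc3-c3ccncc3)CC2)cn1` carries pyridin-4-yl in place of 1-(tert-butyl)-1H-pyrazol-4-yl on an aromatic carbon. Two measured changes at that carbon bear on this: an at least 32-fold higher number from compound 1 to compound 3 (1.51 log units; beyond the scatter), and the modest step already given. Neither involves pyridin-4-yl, so the guide is only that losing the 1-(tert-butyl)-1H-pyrazol-4-yl group should bring this assay down, by a modest step rather than a large one. The expected change is a 3.8-fold lower number from compound 3 to compound 4 (0.58 log units; beyond the scatter). Compound 4 is estimated at 120 mL.min-1.g-1, with an expected range of 40 mL.min-1.g-1 to 320 mL.min-1.g-1.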

Compound 4, intrinsic clearance in microsomes: 31 mL.min-1.g-1
Beside the measured number, compound 4's estimate is 3.9-fold (0.59 log units) above it; the whole stated range lies above it.
By their numbers in this assay, from the lowest: compound 4; then compound 2; then compound 3. At a limit, below all of these: compound 1.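

In this assay, an aromatic ring at this carbon need not bring fast clearance: pyridin-4-yl in place of 1-(tert-butyl)-1H-pyrazol-4-yl gives a 15-fold lower number from compound 3 to compound 4 (1.17 log units; beyond the scatter). Pyridin-4-yl also improves on 4-hydroxybut-1-yn-1-yl, with a 2.2-fold lower number from compound 2 to compound 4 (0.34 log units; beyond the scatter). Methoxy still gives the lowest reading, with an at least 2.2-fold higher number from compound 1 to compound 4 (0.34 log units; beyond the scatter), but that step rests on a limit and not on a number: the limit of < 14 mL.min-1.g-1 in this assay, at which 1 of the 4 values shown sits.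

The compounds shown do not separate the tert-butyl group from the pyrazole ring. They also leave open how an unsubstituted pyrazole, a pyridin-3-yl group or a small amine would read at this carbon.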